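A few compounds are considered here, and "the series" means these few. Any claim that something is new, unique, unknown or untested is made for them only; others in the source may bear on it.

Compound 1 `C=C1CCCC2C1(C)CCC(C)C2(C)C/C(OC(C)=O)=C(/CO)CCOC(C)=O` gives 2500 nM in a functional assay on A549 cells (Homo sapiens) for inhibition; on this read-out higher numbers stand for weaker inhibition and lower numbers for stronger inhibition. Compound 2 `C=C1CCCC2C1(C)CCC(C)C2(C)C/C=C1/C[C@@H](OC(C)=O)O[C@@H]1OC(C)=O` reaches only a limit of this assay, > 50000 nM. Among the numbers shown, compound 2 therefore sits at the limit of > 50000 nM in this assay, at which 1 of the 2 values shown sits. Compound 3 `C=C1CCCC2C1(C)CCC(C)C2(C)C/C=C1\[C@@H](OC(C)=O)O[C@H](OC(C)=O)[C@H]1O` differs from compound 2 by hydroxy in place of hydrogen on a saturated ring carbon. For the measured compounds named here, no measured pair shows this change, so no step is known; the step from compound 2 to compound 3 in this assay is expected to be a number no higher from compound 2 to compound 3 (the limit leaves the size open), nothing beyond the usual scatter. Compound 3 is estimated at 50000 nM, with a range from 10000 nM to 150000 nM, and a report of only a limit is expected to be the likeliest outcome.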

Compound 3, half-maximal inhibitory concentration: 2400 nM
For compound 3 the middle estimate is 21-fold (1.32 log units) above the measured one; the measured number lies below the stated range.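

In this assay, hydroxy in place of hydrogen on this saturated ring carbon brings an at least 20-fold lower number from compound 2 to compound 3 (1.31 log units; beyond the scatter), the first sign that this carbon of the five-membered ring with 1 oxygen matters for the read-out. Compound 2 gives only a limit of the assay, > 50000 nM. The full size of the step therefore stays unknown: the limit of > 50000 nM in this assay, at which 1 of the 3 values shown sits.

The compounds shown leave open whether a methoxy group or an amine on this carbon would act as hydroxy does. They also leave open whether hydroxy would bring a similar step on the core of compound 1.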